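The compounds below may be only part of what the source reports. "The series", "measured", "known", "first", "only" and "open" are said of these compounds alone.

Measured compounds:
compound 1 `CCc1nc(NC(CC)CC)c(F)nc1-c1ccc(Cl)cc1Cl`: 1.22 h
compound 2 `CCc1nc(NC(CC)CC)c(OC)nc1-c1ccc(OC)cc1C(F)(F)F`: 2 h

In an in vitro ADME assay on microsomes (Homo sapiens) for metabolic stability (a lower number here means that the compound disappears faster, a higher number that the compound lasts longer), compound 1 gives 1.22 h, the smaller of the two numbers shown, although the gap to compound 2, which gives 2 h, lies within the scatter of repeated measurements. Compound 3 `CCc1nc(NC(CC)CC)c(Cl)nc1-c1ccc(Cl)cc1Cl` differs from compound 1 by chloro in place of fluoro on an aromatic carbon. Among the compounds with values here, no measured pair shows this change, so nothing fixes its size. A step from compound 1 to compound 3 of no more than the scatter is expected, a 1.1-fold higher number from compound 1 to compound 3 (0.03 log units; within the scatter). Compound 3 is therefore estimated at 1.3 h, with a range from 0.6 h to 2.8 h.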

Compound 3, half-life: 0.167 h
Compound 3: the middle estimate sits 7.8-fold (0.89 log units) above what was measured; the whole stated range lies above it.
By their numbers in this assay, from the lowest: compound 3; then compounds 1 and 2 (each within the scatter of the next).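

In this assay this aromatic carbon, next to the ring nitrogen and ortho to the (pentan-3-yl)amino group, proves sensitive to a single-atom change: chloro in place of fluoro gives a 7.3-fold lower number from compound 1 to compound 3 (0.86 log units; beyond the scatter) and so moves the number beyond the scatter. Compound 1 and compound 2 differ in more than one place and could not show what this position alone does. Nothing available accounts for the size of this step.

As far as these compounds go, whether a methyl group, a nitrile or an amine at this carbon would stay near compound 1 or near compound 3 remains open. So does whether the step would be the same size with the methoxy and trifluoromethyl groups of compound 2 on the outer aromatic ring.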